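Fluoro for hydrogen on compound 1: expected cytotoxicity

The source may report more compounds than this note shows. Statements on the series, on what has been measured and on what is new or still open speak of the compounds shown alone.

compound 1 `N/C(=N\NC(=S)N1CCCCCC1)c1ccccn1`: 6000 nM
compound 2 `Cc1cccc(/C(N)=N/NC(=S)N2CCCCCC2)n1`: 1000 nM
compound 3 `N/C(=N\NC(=S)N1CCCCCC1)c1ccc(F)cn1`: not yet measured

For the measured compounds named here, in a functional assay on HeLa cells (Homo sapiens) for cytotoxicity, read by MTT assay, with a stated time of 72 h (on this read-out higher numbers stand for weaker inhibition and lower numbers for stronger inhibition), compound 1 holds the highest of the two numbers measured; the one measured step, a 6.0-fold lower number from compound 1 to compound 2 (0.78 log units; beyond the scatter), is modest and beyond the scatter. Compound 3 differs from compound 1 by fluoro in place of hydrogen on an aromatic carbon. The measured methyl step sits at a different place on the core of compound 1, so it bears only loosely here; at most a modest step toward a lower number, or none beyond the scatter, is expected. For compound 3 the estimate in this assay is 4000 nM, range 1500 nM to 12000 nM, meaning an expected 1.5-fold lower number from compound 1 to compound 3 (0.18 log units; within the scatter).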

Compound 3, half-maximal inhibitory concentration: 900 nM
Estimate against measurement, compound 3: 4.4-fold (0.65 log units) above; the measured number lies below the stated range.
By their numbers in this assay, from the lowest: compounds 3 and 2 (each within the scatter of the next); then compound 1.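

In this assay, fluoro on the aromatic carbon para to a large group gives a 6.7-fold lower number from compound 1 to compound 3 (0.82 log units; beyond the scatter) and so shows that this position responds to a single fluorine atom. For the compounds shown here, until now the only step on the core of compound 1 was the methyl change at a different place, a 6.0-fold lower number from compound 1 to compound 2 (0.78 log units; beyond the scatter). Nothing available explains the step at this position.

From the compounds shown here alone, whether chlorine, a methoxy group or an amine on this same carbon would give a similar step remains open. So does whether the fluoro and methyl changes would add together on one core.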